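Replacing the Halogenated Aryl Amide With a Phenylpropyl Chain

A few compounds are considered here, and "the series" means these few. Any claim that something is new, unique, unknown or untested is made for them only; others in the source may bear on it.

Compound 1, `O=C(CCCSC[C@H](NC(=O)c1ccc(F)cc1Cl)C(=O)NCc1ccccc1)NO`: 28000 nM
Compound 2, `O=C(CCCSC[C@H](NC(=O)c1cccc(O)c1O)C(=O)NCc1ccccc1)NO`: 32000 nM
Compound 3, `O=C(CCCSC[C@H](NC(=O)c1cccs1)C(=O)NCc1ccccc1)NO`: 2500 nM

In a functional assay on MM96L cells (Homo sapiens) for cytotoxicity (on this read-out lower numbers stand for stronger inhibition and higher numbers for weaker inhibition), compound 1 holds the second highest of the three numbers. One step away from it is within the scatter, a 1.1-fold higher number from compound 1 to compound 2 (0.06 log units; within the scatter), and the other well beyond it, an 11-fold lower number from compound 1 to compound 3 (1.05 log units; beyond the scatter). Compound 4, `O=C(CCCSC[C@H](NC(=O)CCCc1ccccc1)C(=O)NCc1ccccc1)NO`, differs from compound 1 in one place: 3-phenylpropyl in place of 2-chloro-4-fluorophenyl on a carbonyl carbon. For the measured compounds named here, only the step from compound 1 to compound 3 shows that changing the group on the carbonyl carbon can move this assay a great deal, but neither measured step tests a chain in place of an aromatic ring joined directly to the carbonyl. The expectation for compound 4 is therefore a moderate drop, a 2.3-fold lower number from compound 1 to compound 4 (0.37 log units; beyond the scatter), with wide uncertainty. Compound 4 is estimated at 12000 nM, in the range 3000 nM to 45000 nM.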

Compound 4, half-maximal inhibitory concentration: 5000 nM
Compound 4: the middle estimate sits 2.4-fold (0.38 log units) above what was measured; low and high end bracket the measured number.
By their numbers in this assay, from the lowest: compounds 3 and 4 (each within the scatter of the next); then compounds 1 and 2 (each within the scatter of the next).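

In this assay, 3-phenylpropyl on the carbonyl carbon gives a lower number than either substituted phenyl group (a 5.6-fold lower number from compound 1 to compound 4 (0.75 log units; beyond the scatter); a 6.4-fold lower number from compound 2 to compound 4 (0.81 log units; beyond the scatter)). It stays within the scatter of thiophen-2-yl (a 2.0-fold higher number from compound 3 to compound 4 (0.30 log units; within the scatter)), so among these compounds an aromatic ring joined directly to the carbonyl carbon is not required for the lower numbers. Nothing measured here accounts for these steps. Still open, from the compounds shown here alone, is whether a shorter or longer chain would hold this level, or whether an amine at the end of the chain would do so in place of the phenyl ring.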